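The source may hold more compounds than are shown below. What is called first, only, known or untested is meant among the compounds shown, and "the series" means these compounds.

Three measured compounds share one core and differ only in the chain on the saturated ring. Compound 1 `Cn1ncc(Cl)c1-c1cc(C(=O)N[C@@H]2CN[C@H](CCN3CCC(O)CC3)C[C@H]2c2ccc(Cl)c(Cl)c2)oc1Cl` carries a hydroxypiperidinyl on that chain and in an assay for inhibition of RAC-alpha serine/threonine-protein kinase (Homo sapiens), read by HTRF, with a stated time of 1 h (a lower number here means a stronger inhibitor, a higher number a weaker inhibitor), compound 1 gives 5.99 nM. Compound 2 `Cn1ncc(Cl)c1-c1cc(C(=O)N[C@@H]2CN[C@H](CCCO)C[C@H]2c2ccc(Cl)c(Cl)c2)oc1Cl` carries a hydroxypropyl chain and in this assay compound 2 gives 2.56 nM. Compound 3 `Cn1ncc(Cl)c1-c1cc(C(=O)N[C@@H]2CN[C@H](CC(N)=O)C[C@H]2c2ccc(Cl)c(Cl)c2)oc1Cl` carries a carbamoylmethyl chain and in this assay compound 3 gives 3.24 nM. Compound 3 sits within the scatter of both neighbours, as a 1.8-fold lower number from compound 1 to compound 3 (0.27 log units; within the scatter) and a 1.3-fold higher number from compound 2 to compound 3 (0.10 log units; within the scatter) show; only a 2.3-fold lower number from compound 1 to compound 2 (0.37 log units; beyond the scatter) goes beyond it, and modestly.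

Compound 4 `Cn1ncc(Cl)c1-c1cc(C(=O)N[C@@H]2CN[C@H](CC(=O)NC3CC3)C[C@H]2c2ccc(Cl)c(Cl)c2)oc1Cl` differs from compound 3 by cyclopropyl in place of hydrogen on an amide-type nitrogen. Going by the values given here, no measured step tests this exact change. The steps that exist all swap the chain group, and each stays small, which suggests the chain end tolerates change without a large move in this assay. The number for compound 4 in this assay is therefore expected to stay close to compound 3, with a 1.1-fold higher number from compound 3 to compound 4 (0.03 log units; within the scatter) as the estimated step. The estimate for compound 4 is 3.5 nM, expected to fall between 1.5 nM and 9 nM.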

Compound 4, half-maximal inhibitory concentration: 3.95 nM
The estimate for compound 4 lay 1.1-fold (0.05 log units) below the measured number, within the range that was stated.
By their numbers in this assay, from the lowest: compounds 2, 3, 4 and 1 (each within the scatter of the next, the first and the last beyond it).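

Replacing the amide hydrogen of compound 3 with cyclopropyl causes no change beyond the scatter in this assay (a 1.2-fold higher number from compound 3 to compound 4 (0.09 log units; within the scatter)), which gives the first direct test on the amide nitrogen itself rather than a swap of the whole chain group. The cyclopropylcarbamoyl chain also stays within the scatter when set against the hydroxypropyl chain (a 1.5-fold higher number from compound 2 to compound 4 (0.19 log units; within the scatter)) and against the chain ending in hydroxypiperidinyl (a 1.5-fold lower number from compound 1 to compound 4 (0.18 log units; within the scatter)). No supporting data are available to explain why these numbers stay so close.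

The compounds shown leave open whether this nitrogen would accept a larger ring such as cyclohexyl or a longer chain such as butyl. They also leave open whether a carboxylic acid in place of the carbamoyl group would keep the number in this range.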